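From methoxy to ethoxy in the series

The source may hold more compounds than are shown below. What is called first, only, known or untested is meant among the compounds shown, and "the series" means these compounds.

For the measured compounds named here, in a functional assay on K562 cells (Homo sapiens) for antiproliferative activity, read by MTT assay, with a stated time of 72 h (a lower number here means a stronger inhibitor, a higher number a weaker inhibitor), compound 1 (`COc1ccc(-c2c(C(=O)c3cc(OC)c(OC)c(OC)c3)sc3ccccc23)cc1`) gives 1700 nM, the lower of the two numbers so far. Compound 2 (`COc1ccc(-c2c(C(=O)c3cc(OC)c(OC)c(OC)c3)sc3ccccc23)c(OC)c1`) gives 4100 nM. Going by the values given here, the only measured step, a 2.4-fold higher number from compound 1 to compound 2 (0.38 log units; beyond the scatter), is modest and comes with methoxy in place of hydrogen on an aromatic carbon.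

Next in line is compound 3 (`CCOc1ccc(-c2c(C(=O)c3cc(OC)c(OC)c(OC)c3)sc3ccccc23)cc1`), which turns 4-methoxyphenyl into 4-ethoxyphenyl: methyl in place of hydrogen on a saturated chain carbon bound to an oxygen on an aromatic ring. Among the compounds with values here, no measured step makes this same change. Within the data shown here, the one available guide is a different change in a different place, a 2.4-fold higher number from compound 1 to compound 2 (0.38 log units; beyond the scatter), so it bears on the new step only loosely. It shows one addition to the core of compound 1 raising the number, and no addition has yet lowered it. A small rise is therefore expected in this assay, possibly none beyond the scatter. The expected step is a 1.5-fold higher number from compound 1 to compound 3 (0.17 log units; within the scatter). For compound 3 the estimate is 2500 nM, with an expected range of 900 nM to 7000 nM.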

Compound 3, half-maximal inhibitory concentration: 3100 nM
Compound 3: the middle estimate sits 1.2-fold (0.09 log units) below what was measured; measured number inside the range.
By their numbers in this assay, from the lowest: compounds 1, 3 and 2 (each within the scatter of the next, the first and the last beyond it).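

In this assay, for the compounds shown here, the change from methoxy to ethoxy, with methyl in place of hydrogen on a saturated chain carbon bound to an oxygen on an aromatic ring, gives a 1.8-fold higher number from compound 1 to compound 3 (0.26 log units; within the scatter), so this single added methyl does not separate compound 3 from compound 1, unlike the added methoxy of compound 2, the only earlier change. The swap of 2,4-dimethoxyphenyl for 4-ethoxyphenyl gives a 1.3-fold lower number from compound 2 to compound 3 (0.12 log units; within the scatter), so compound 3 cannot be told apart from compound 2 either, even though compound 1 and compound 2 stand apart, and the three compounds do not fall into separate levels. Nothing measured here accounts for where these numbers fall.

Still open, going by these compounds, is whether a longer chain, such as propoxy, or an amine, such as dimethylamino, in place of the 4-methoxy group would move the number beyond the scatter from compound 1. Also open, on these data alone, is whether the same change from methoxy to ethoxy on the other methoxy groups of compound 1 would give a comparable step.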